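The compounds below may be only part of what the source reports. "The series", "measured", "known", "first", "only" and "open" are said of these compounds alone.

Of the compounds shown here, two built on the same core have been measured so far. Compound 1, `COc1cc2ccc(=O)oc2cc1OCCCCBr`, carries a bromo-terminated chain on the core; in a functional assay on HUVEC cells (Homo sapiens) for inhibition, read by MTT assay, with a stated time of 24 h, tested at 10 uM (on this read-out lower numbers stand for less inhibition of growth and higher numbers for more inhibition of growth at the one concentration tested), compound 1 gives 11.2%. Compound 2, `COc1cc2ccc(=O)oc2cc1OCC(=O)c1ccc(F)cc1`, carries instead a carbonyl bearing a fluoro-substituted aromatic ring; in this assay compound 2 gives 3.6%. Of the two numbers, compound 2 stands at the lower one, and its nearest neighbour is compound 1, whose number lies within the usual scatter of it, so no order can be read between them.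

The next compound, compound 3, `COc1cc2ccc(=O)oc2cc1OCC(=O)c1ccc([N+](=O)[O-])cc1`, differs from compound 2 in one place: nitro in place of fluoro on an aromatic carbon. The change sits on an aromatic carbon of a six-membered aromatic ring of carbon only, para to a large group.

For the measured compounds named here, no step between two measured compounds is available to size this change against. With compound 2 at 3.6% and compound 1 at 11.2% both low, the expectation is a step in this assay of no size beyond the scatter, in either direction. Compound 3 is therefore estimated at 8%, between -5% and 22%, an expected step of a number 4.4 percentage points higher from compound 2 to compound 3 (within the scatter).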

Compound 3, percent growth inhibition at one concentration: 4.1%
Compound 3: the middle estimate sits 3.9 percentage points above what was measured; low and high end bracket the measured number.
By their numbers in this assay, from the lowest: compounds 2, 3 and 1 (each within the scatter of the next).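

In this assay, for the compounds shown here, nitro in place of fluoro on an aromatic carbon, para to a large group, gives a number 0.5 percentage points higher from compound 2 to compound 3 (within the scatter), and this is the first step in this assay that can be sized between two compounds differing in one place. At this position, a fluoro of 1 heavy atom and no hydrogen-bond acceptors gives way to a nitro of 3 heavy atoms and 2 hydrogen-bond acceptors, yet the read-out does not leave the usual scatter, so this single change gives no sign that the position affects growth inhibition at the one concentration tested. No measurement among those available bears on why this exchange leaves the number within the scatter.

What the compounds shown leave open is whether any group on this aromatic carbon can carry the read-out beyond the scatter, as neither fluoro nor nitro does so, and an amine or a carboxylic acid there would be a further test of this position. They also leave open whether a longer chain in place of the carbonyl-bearing side chain on the shared core would change the picture.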